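The source may report more compounds than this note shows. Statements on the series, on what has been measured and on what is new or still open speak of the compounds shown alone.

In a functional assay on the whole organism for inhibition, with Rattus norvegicus as the target, read by paw edema, with stated times of 1 h and 3 h (a lower number here means that less compound is needed, a higher number that more compound is needed for the effect), compound 1 `C/C(=N\OCC(N)=O)c1ccc(Cl)cc1` gives 24 mg/kg and sits within the scatter of compound 3 `C/C(=N\NCC(=O)O)c1ccc(Cl)cc1` at 22 mg/kg while compound 2 `C/C(=N\OCC(N)=O)c1ccc(Cl)c(Cl)c1` stands on the higher side at 55 mg/kg in this set. Compound 4 `CNC(=O)CO/N=C(\C)c1ccc(Cl)cc1` differs from compound 1 by methyl in place of hydrogen on an amide-type nitrogen. Within the data shown here, no measured step touches that nitrogen. Chloro in place of hydrogen on an aromatic carbon gave a 2.3-fold higher number from compound 1 to compound 2 (0.36 log units; beyond the scatter) and the change to (carboxymethyl)amino on the double-bonded nitrogen gave a 1.1-fold lower number from compound 1 to compound 3 (0.04 log units; within the scatter) so neither step at hand is large. In this assay the expected change is therefore small: an estimated 1.3-fold higher number from compound 1 to compound 4 (0.10 log units; within the scatter) with nothing expected beyond the scatter. Compound 4 is estimated at 30 mg/kg (expected range 14 mg/kg to 60 mg/kg).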

Compound 4, dose for half-maximal effect: 70 mg/kg
For compound 4 the middle estimate is 2.3-fold (0.37 log units) below the measured one; the whole stated range lies below it.
By their numbers in this assay, from the lowest: compounds 3 and 1 (each within the scatter of the next); then compounds 2 and 4 (each within the scatter of the next).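

In this assay, among these compounds, methyl in place of hydrogen on the amide-type nitrogen gives a 2.9-fold higher number from compound 1 to compound 4 (0.46 log units; beyond the scatter), so this nitrogen, which no earlier step touched, responds to a single added carbon with a modest change beyond the scatter. The number moves in the same direction as with the chloro step, a 2.3-fold higher number from compound 1 to compound 2 (0.36 log units; beyond the scatter). Nothing available here bears on why the methyl has this effect. Going by these compounds, whether ethyl or a longer chain on this nitrogen would move the number further remains open. So does whether the same methyl would give a similar step on compound 2.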